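The source may report more compounds than this note shows. Statements on the series, on what has been measured and on what is new or still open speak of the compounds shown alone.

Compound 2 `CC(C)(C)C(=O)C1=C(O)C(=O)N(c2ccc(-c3ccsc3)cc2)C1c1ccccc1OCCO` is the closest measured neighbour of the new analogue. In a physicochemical assay for solubility, in phosphate buffer, at pH 6.8 (a higher number here means a more soluble compound, a lower number a less soluble compound), compound 2 gives only the assay limit, > 50000 nM. Compound 1 `CC(C)(C)C(=O)C1=C(O)C(=O)N(c2ccc(-c3ccoc3)cc2)C1c1ccccc1OCCO`, the other measured member, likewise stands at the limit in this assay, > 50000 nM. Going by the values given here, the step that the two limits leave unreadable from compound 1 to compound 2 is therefore not readable, and the limit of > 50000 nM in this assay, at which 2 of the 2 values shown sit, is the only evidence on hand. Compound 3 `CC(C)(C)C(=O)C1=C(O)C(=O)N(c2ccc(-c3cccs3)cc2)C1c1ccccc1OCCO` differs from compound 2 by thiophen-2-yl in place of thiophen-3-yl on an aromatic carbon. Among the compounds with values here, no measured step bears on this change, so the expected move a step that the limit leaves unreadable from compound 2 to compound 3 is none beyond the scatter. Compound 3 is expected at 80000 nM in this assay, within 30000 nM to 200000 nM, most likely again reported only as a limit.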

Compound 3, solubility: 38600 nM
Estimate against measurement, compound 3: 2.1-fold (0.32 log units) above, within the range that was stated.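

Going by these compounds alone, only one of the three compounds now gives a number rather than a limit in this assay, so the attachment point of the thiophene gives a first, partial reading. Thiophen-2-yl in place of thiophen-3-yl gives an at least 1.2-fold lower number from compound 2 to compound 3 (0.11 log units; that floor lies within the scatter), and thiophen-2-yl in place of furan-3-yl gives an at least 1.2-fold lower number from compound 1 to compound 3 (0.11 log units; that floor lies within the scatter); both are floors, so the true size of either step remains unknown. The step between the other two compounds cannot be read: the limit of > 50000 nM in this assay, at which 2 of the 3 values shown sit.

From the compounds shown here alone, whether furan-2-yl would follow thiophen-2-yl remains open. So does the effect of an amine or a carboxylic acid at this position.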